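Chloro on the anilino phenyl of compound 2

A few compounds are considered here, and "the series" means these few. Any claim that something is new, unique, unknown or untested is made for them only; others in the source may bear on it.

Values in an in vitro assay on HEK-tsA201 cells for antagonist activity at Neuronal acetylcholine receptor; alpha3/beta4 (Homo sapiens), read by fluorescence and calcium flux (on this read-out lower numbers stand for stronger inhibition and higher numbers for weaker inhibition), so far:
compound 1 `CCCNc1cccc(NC(=O)c2ccc(OCCC)cc2)n1`: 12600 nM
compound 2 `CCCOc1ccc(C(=O)Nc2cccc(Nc3ccccc3)n2)cc1`: > 100000 nM, a limit of the assay and not a number

Compound 2 stands only at the limit (the limit of > 100000 nM in this assay, at which 1 of the 2 values shown sits); no number for it is known, so its position relative to any other compound can be fixed only from below. For the measured compounds named here, the single measured step, an at least 7.9-fold higher number from compound 1 to compound 2 (0.89 log units; beyond the scatter), is one of weakening, and it runs into that limit, so its true size is open.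

Compound 3 `CCCOc1ccc(C(=O)Nc2cccc(Nc3ccc(Cl)cc3)n2)cc1` differs from compound 2 by chloro in place of hydrogen on an aromatic carbon. Going by the values given here, no measured step touches a substituent on that phenyl; the one step known concerns the group on the ring nitrogen of the core, not a substituent on it. Nothing in the measured pair therefore speaks for a change beyond the scatter in this assay on going to compound 3, and the starting point is already the limit.

The expectation is that compound 3 again reports a limit or a weak value, estimated at 100000 nM with a range 30000 nM to 300000 nM. The expected step of a number no higher from compound 2 to compound 3 (the limit leaves the size open) is none beyond the scatter.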

Compound 3, half-maximal inhibitory concentration: > 100000 nM
Compound 3 was reported as a limit; the forecaster's own chance of this, stated with the estimate: 65%; the middle value lies on the limit itself.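

In this assay compound 3 gives > 100000 nM, which is a limit of the assay and not a number. With 4-chlorophenyl in place of propyl on the nitrogen, the result is an at least 7.9-fold higher number from compound 1 to compound 3 (0.89 log units; beyond the scatter), so the loss seen with the plain phenyl also holds with chloro on that ring, and chloro in this place does not bring the compound back into the measurable range. The step between compound 2 and compound 3 cannot be read, and the series now has two compounds resting at the same edge of the read-out: the limit of > 100000 nM in this assay, at which 2 of the 3 values shown sit.

Going by these compounds, whether chloro has any effect at all on the anilino phenyl stays open, since neither compound 2 nor compound 3 gives a number, and a methoxy group or a dimethylamino group in the same place would face the same question. Also open, on these data alone, is whether a longer chain, a benzyl group or a chain ending in an amine on that nitrogen would hold or improve on compound 1, which gives 12600 nM in this assay.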